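Swapping the aryl group of an oxime ether agonist

The compounds below may be only part of what the source reports. "The series", "measured", "known", "first", "only" and "open" are said of these compounds alone.

Measured compounds:
compound 1 `Clc1ccc(CO/N=C/c2c(-c3ccc4ccccc4c3)nc3occn23)cc1Cl`, 370 nM
compound 2 `CC(C)(C)c1ccc(CO/N=C/c2c(-c3ccc4ccccc4c3)nc3occn23)cc1`, 7900 nM
compound 3 `FC(F)(F)c1ccc(CO/N=C/c2c(-c3ccc4ccccc4c3)nc3occn23)cc1`, 470 nM

All three were tested in an assay on HepG2 cells for agonist activity at nuclear receptor subfamily 1 group I member 3 (Homo sapiens), read by a luciferase reporter, with a stated time of 23 h; a higher number here means that more compound is needed for the effect, a lower number that less compound is needed. Compound 3 holds the second-highest number of the three; compound 1 sits closest, as a 1.3-fold higher number from compound 1 to compound 3 (0.10 log units; within the scatter) shows, while compound 2 is furthest, as a 17-fold lower number from compound 2 to compound 3 (1.23 log units; beyond the scatter) shows. Compound 4 `Clc1ccc(CO/N=C/c2c(-c3ccc4ccccc4c3)nc3occn23)c(Cl)c1` is not yet measured. Its change from compound 3 is 2,4-dichlorophenyl in place of 4-(trifluoromethyl)phenyl on a saturated chain carbon bound to an oxygen on an unsaturated carbon. Among the measured compounds shown here, two steps bear on it: a 1.3-fold higher number from compound 1 to compound 3 (0.10 log units; within the scatter), which links a dichlorophenyl to the trifluoromethylphenyl with no movement beyond the scatter, and a 21-fold higher number from compound 1 to compound 2 (1.33 log units; beyond the scatter), a large one, which shows the aryl group matters. A chlorinated phenyl has so far stayed close to compound 3, so compound 4 is expected to land near it, with a 1.1-fold higher number from compound 3 to compound 4 (0.03 log units; within the scatter). The estimate for compound 4 is 500 nM, ranging from 150 nM to 2000 nM.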

Compound 4, half-maximal effective concentration: 1500 nM
Compound 4: middle estimate off by 3.0-fold (0.48 log units), on the low side, and the stated range covers the measured number.
By their numbers in this assay, from the lowest: compounds 1 and 3 (each within the scatter of the next); then compound 4; then compound 2.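

At this position the placing of the chlorines counts: 2,4-dichlorophenyl in place of 3,4-dichlorophenyl gives a 4.1-fold higher number from compound 1 to compound 4 (0.61 log units; beyond the scatter) and so two dichlorophenyl groups need not behave alike. The same group gives a 3.2-fold higher number from compound 3 to compound 4 (0.50 log units; beyond the scatter) and also a 5.3-fold lower number from compound 2 to compound 4 (0.72 log units; beyond the scatter) so compound 4 takes a middle place in the order. Nothing at hand explains these differences. Still open, from the compounds shown here alone, is how a phenyl carrying a single chlorine would compare with these groups. So is the effect of an amine or a carboxylic acid on that ring.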